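Working notes: from compound 2 to compound 3

A few compounds are considered here, and "the series" means these few. Any claim that something is new, unique, unknown or untested is made for them only; others in the source may bear on it.

Measured in a functional assay on B16-F10 cells (Mus musculus) for antiproliferative activity, read by CCK-8 assay, with a stated time of 48 h; a higher number here means a weaker inhibitor, a lower number a stronger inhibitor:
- compound 1 `COc1ccc(/C=C\c2cc(OC)c(OC)c(OC)c2)cc1OCc1ccc(CO)cc1` gives 6600 nM
- compound 2 `COc1ccc(/C=C\c2cc(OC)c(OC)c(OC)c2)cc1OCc1ccc(CNCCN(C)C)cc1` gives > 10000 nM as a limit of the assay

Compound 2 has no number in this assay, only a limit (> 10000 nM). The next structure is compound 3 `COc1ccc(/C=C\c2cc(OC)c(OC)c(OC)c2)cc1OCc1ccc(CN2CCCCC2C(=O)NCCN)cc1`, and the change is 2-((2-aminoethyl)carbamoyl)piperidin-1-yl in place of (2-(dimethylamino)ethyl)amino on a saturated chain carbon bound to an aromatic carbon. Among the compounds with values here, one measured step bears on this place, an at least 1.5-fold higher number from compound 1 to compound 2 (0.18 log units; that floor lies within the scatter), so no step beyond the scatter is expected in this assay, and no direction can be expected either. That step ends at the limit of > 10000 nM in this assay, at which 1 of the 2 values shown sits, so its full size is not known. The step estimated here is a number no higher from compound 2 to compound 3 (the limit leaves the size open), and a report of only a limit is expected to be slightly more likely than not. Compound 3 is estimated at 10000 nM, with an expected range from 3000 nM to 30000 nM.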

Compound 3, half-maximal inhibitory concentration: 4600 nM
Estimate against measurement, compound 3: 2.2-fold (0.34 log units) above, within the range that was stated.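

In this assay, the saturated chain carbon bound to an aromatic carbon now shows a change beyond the scatter, with 2-((2-aminoethyl)carbamoyl)piperidin-1-yl in place of (2-(dimethylamino)ethyl)amino: an at least 2.1-fold lower number from compound 2 to compound 3 (0.33 log units; beyond the scatter). Set against hydroxy at the same place, the larger group gives a 1.4-fold lower number from compound 1 to compound 3 (0.16 log units; within the scatter), so hydroxy and 2-((2-aminoethyl)carbamoyl)piperidin-1-yl are not told apart in this assay, and this place accepts a group of this size without a step beyond the scatter. The full size of the step to compound 3 stays unknown, since compound 2 has only a limit of the assay: the limit of > 10000 nM in this assay, at which 1 of the 3 values shown sits.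

The piperidine ring and the 2-aminoethyl carbamoyl part enter together in one change, so the compounds shown do not say which of them carries the step from the (2-(dimethylamino)ethyl)amino compound. A plain piperidin-1-yl group, or a carboxylic acid in place of the 2-aminoethyl amide, would separate these two parts at this place.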